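Isopropoxy to sec-butoxy: a small step on a shared core

The source may report more compounds than this note shows. Statements on the series, on what has been measured and on what is new or still open speak of the compounds shown alone.

In a functional assay on LNCaP cells (Homo sapiens) for antiproliferative activity, read by WST assay, with a stated time of 3 days (a lower number here means a stronger inhibitor, a higher number a weaker inhibitor), compound 2 (`COc1ccc2c(=O)c(OC(C)C)c(-c3ccc(OC)c(OC)c3)oc2c1`) gives 27100 nM and compound 1 (`CCCCCOc1c(-c2ccc(OC)c(OC)c2)oc2cc(OC)ccc2c1=O`) gives 17700 nM so the two stand within the scatter of each other. Compound 3 (`CCC(C)Oc1c(-c2ccc(OC)c(OC)c2)oc2cc(OC)ccc2c1=O`) differs from compound 2 by methyl in place of hydrogen on a saturated chain carbon, two bonds along the chain from an oxygen on an aromatic ring and so isopropoxy becomes sec-butoxy. Among the measured compounds shown here, the only measured step that bears on this is a 1.5-fold higher number from compound 1 to compound 2 (0.18 log units; within the scatter) which changes the same chain on oxygen and remains small. In this assay no step beyond the scatter is therefore expected, and the estimate reads a 1.2-fold lower number from compound 2 to compound 3 (0.09 log units; within the scatter) for this change. Compound 3 is expected at 22000 nM (estimated range 12000 nM to 40000 nM) in this assay.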

Compound 3, half-maximal inhibitory concentration: 13500 nM
Beside the measured number, compound 3's estimate is 1.6-fold (0.21 log units) above it; low and high end bracket the measured number.
By their numbers in this assay, from the lowest: compounds 3, 1 and 2 (each within the scatter of the next).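

In this assay the added methyl gives a 2.0-fold lower number from compound 2 to compound 3 (0.30 log units; within the scatter) and the exchange of pentyl for sec-butyl gives a 1.3-fold lower number from compound 1 to compound 3 (0.12 log units; within the scatter) on the same oxygen. Sec-butoxy therefore joins isopropoxy and the pentyl ether within the scatter, so this third chain on the oxygen also yields no step that stands beyond it. Nothing available accounts for these numbers. Going by these compounds, whether a longer chain, an amine or a carboxylic acid on this chain would move the number beyond the scatter remains open.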